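Adding a second chloro to a weak cytotoxic hydrazone

The compounds below may be only part of what the source reports. "The series", "measured", "known", "first", "only" and "open" are said of these compounds alone.

Compound 1, `Cn1nnnc1SCC(=O)N/N=C/c1ccc(Cl)cc1`, gives 100000 nM in a functional assay on A549 cells (Homo sapiens) for cytotoxicity, read by XTT assay, with a stated time of 24 h; a higher number here means a weaker inhibitor, a lower number a stronger inhibitor.
Compound 2, `Cn1nnnc1SCC(=O)N/N=C/c1ccc(O)cc1`, gives only a limit of the assay in this assay, > 10000000 nM.
Compound 3, `COc1ccc(/C=N/NC(=O)CSc2nnnn2C)cc1`, likewise gives only a limit in this assay, > 10000000 nM.

Compound 1 thus holds the only real number shown; the other two values sit at the limit of > 10000000 nM in this assay, at which 2 of the 3 values shown sit. Compound 4, `Cn1nnnc1SCC(=O)N/N=C/c1ccc(Cl)cc1Cl`, differs from compound 1 by chloro in place of hydrogen on an aromatic carbon. Within the data shown here, no measured step adds a group to compound 1; the measured steps only swap its chloro away: an at least 100-fold higher number from compound 1 to compound 2 (2.00 log units; beyond the scatter) and an at least 100-fold higher number from compound 1 to compound 3 (2.00 log units; beyond the scatter), both large. Those steps show that removing the chloro lost measurable activity, but say nothing about a second chloro, so in this assay no step beyond the scatter is expected. Compound 4 is therefore expected near 70000 nM, between 20000 nM and 300000 nM. The expected step, a 1.4-fold lower number from compound 1 to compound 4 (0.15 log units; within the scatter), is small.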

Compound 4, half-maximal inhibitory concentration: 500000 nM
Estimate against measurement, compound 4: 7.1-fold (0.85 log units) below, outside the stated range (above it).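

In this assay, a second chloro, ortho to a large group and meta to the first chloro, gives a 5.0-fold higher number from compound 1 to compound 4 (0.70 log units; beyond the scatter). Among these compounds, this is the first step that adds a group to compound 1 rather than swapping its chloro away, and it shows that the added group weakens the compound at this position. Compound 4 still gives a real number rather than a limit of the assay.

From the compounds shown here alone, whether a methyl or an amine at this position would weaken the compound in the same way remains open. So does whether a second chloro on another carbon of the ring would do so.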